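The source may report more compounds than this note shows. Statements on the series, on what has been measured and on what is new or still open speak of the compounds shown alone.

Measured so far in an assay on a cell-free system (plasma) for inhibition of Dipeptidyl peptidase 4 (Rattus norvegicus), read by fluorescence; a lower number here means a stronger inhibitor, a higher number a weaker inhibitor:
Compound 1 `O=C([C@@H]1C[C@H](N2CCN(c3cccc(Cl)c3)CC2)CN1)N1CCSC1` gives 7.2 nM.
Compound 2 `O=C([C@@H]1C[C@H](N2CCN(c3ccc(Cl)c(Cl)c3)CC2)CN1)N1CCSC1` gives 4.2 nM.
Compound 3 `N#Cc1ccc(N2CCN([C@@H]3CN[C@H](C(=O)N4CCSC4)C3)CC2)cc1` gives 4.7 nM.

Compound 3 stands second highest of the three numbers in this assay; a 1.1-fold higher number from compound 2 to compound 3 (0.05 log units; within the scatter), and a 1.5-fold lower number from compound 1 to compound 3 (0.19 log units; within the scatter). All three values lie within the scatter of one another, so no order among them is established.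

Compound 4 `O=C([C@@H]1C[C@H](N2CCN(c3ccncc3)CC2)CN1)N1CCSC1` differs from compound 3 in one place: pyridin-4-yl in place of 4-cyanophenyl on an amine nitrogen in a ring.

For the measured compounds named here, the steps that bear on this are the exchanges of the aryl group on the ring nitrogen, a 1.5-fold lower number from compound 1 to compound 3 (0.19 log units; within the scatter) and a 1.1-fold higher number from compound 2 to compound 3 (0.05 log units; within the scatter), together with the substituent change a 1.7-fold lower number from compound 1 to compound 2 (0.23 log units; within the scatter), none of which moved the number beyond the scatter. Going by the values given here, no measured step exchanges the carbon-only aromatic ring for a ring with a hetero atom, and no measured step removes a nitrile without adding another group; the series gives no guide for either. The expectation in this assay is therefore a step within the scatter or a modest rise in the number, a 1.7-fold higher number from compound 3 to compound 4 (0.23 log units; within the scatter). Compound 4 is estimated at 8 nM, with a range from 3 nM to 25 nM.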

Compound 4, half-maximal inhibitory concentration: 3.9 nM
Compound 4: the middle estimate sits 2.1-fold (0.31 log units) above what was measured, and the stated range covers the measured number.
By their numbers in this assay, from the lowest: compounds 4, 2, 3 and 1 (each within the scatter of the next).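

In this assay, pyridin-4-yl on the amine nitrogen in the ring stays within the scatter of all three aryl groups before it (a 1.2-fold lower number from compound 3 to compound 4 (0.08 log units; within the scatter); a 1.1-fold lower number from compound 2 to compound 4 (0.03 log units; within the scatter); a 1.8-fold lower number from compound 1 to compound 4 (0.27 log units; within the scatter)). The earlier compounds shown here showed this only for aromatic rings of carbon only; this position now also takes a six-membered aromatic ring with 1 hetero atom, and the change from 4-cyanophenyl removes the nitrile and goes from 8 heavy atoms to 6 without a step beyond the scatter. No measurement offered here accounts for this flat response.

Open, from the compounds shown here alone, is whether a non-aromatic group on this nitrogen, such as a cyclohexyl ring or a longer alkyl chain, stays within the scatter too. Also open, going by these compounds, is whether an amine or a carboxylic acid on the aromatic ring would move the number beyond it.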